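This account rests on a few compounds, and the source may have more. Where it says the series, first, only, none or still open, it means among the compounds named here.

Compound 1 `Cc1noc(C)c1-c1cnc(N)c(Oc2ccc(C(=O)Nc3ccccc3Cl)cc2)n1`, in a functional assay on LoVo cells (Homo sapiens) for inhibition, read by MTT assay, with a stated time of 72 h; on this read-out lower numbers stand for stronger inhibition and higher numbers for weaker inhibition: > 100000 nM, a limit of the assay rather than a number.
Compound 2 `Cc1noc(C)c1-c1cnc(N)c(Oc2ccc(C(=O)Nc3cccc(Cl)n3)cc2)n1`: 39300 nM
Compound 3 `Cn1cc(-c2cnc(N)c(Oc3ccc(C(=O)Nc4ccccc4Cl)cc3)n2)cn1`: 41400 nM

Among the compounds with values here, only two plain numbers are in hand, and compound 3 and compound 2 sit within the scatter of each other. Compound 1 is represented by a limit alone (the limit of > 100000 nM in this assay, at which 1 of the 3 values shown sits). Compound 4 `Cn1cc(-c2cnc(N)c(Oc3ccc(C(=O)Nc4cccc(Cl)n4)cc3)n2)cn1` has not yet been measured. It differs from compound 3 in a single place: 6-chloropyridin-2-yl in place of 2-chlorophenyl on an amide-type nitrogen. The same exchange has been made once before, on the core of compound 1, and there it gave an at least 2.5-fold lower number from compound 1 to compound 2 (0.40 log units; beyond the scatter). A lower number is therefore expected for compound 4, with a step of roughly a 2.8-fold lower number from compound 3 to compound 4 (0.44 log units; beyond the scatter). The estimate for compound 4 in this assay is 15000 nM, within a range from 4000 nM to 50000 nM.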

Compound 4, half-maximal inhibitory concentration: 48600 nM
Compound 4: the middle estimate sits 3.2-fold (0.51 log units) below what was measured; low and high end bracket the measured number.
By their numbers in this assay, from the lowest: compounds 2, 3 and 4 (each within the scatter of the next). At a limit, above all of these: compound 1.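

In this assay, placing 6-chloropyridin-2-yl on the amide-type nitrogen gives a 1.2-fold higher number from compound 3 to compound 4 (0.07 log units; within the scatter), so the drop seen on the core of compound 1 does not carry over to the 1-methyl-1H-pyrazol-4-yl series: the same change on two cores in this assay, an at least 2.5-fold lower number (0.40 log units; beyond the scatter) from compound 1 to compound 2 and a 1.2-fold higher number (0.07 log units; within the scatter) from compound 3 to compound 4, at least 2.9-fold (0.47 log units) apart, beyond the scatter of two such steps. The pyrazole exchange likewise loses its earlier effect once 6-chloropyridin-2-yl is present, giving a 1.2-fold higher number from compound 2 to compound 4 (0.09 log units; within the scatter): the same change on two cores in this assay, an at least 2.4-fold lower number (0.38 log units; beyond the scatter) from compound 1 to compound 3 and a 1.2-fold higher number (0.09 log units; within the scatter) from compound 2 to compound 4, at least 2.9-fold (0.47 log units) apart, beyond the scatter of two such steps. Both earlier drops start from compound 1, whose > 100000 nM is a limit, not a number.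

Why each change depends on the other stays open. So does whether a carboxylic acid or an amine on the ring attached to the amide-type nitrogen would shift the number.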